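The compounds below may be only part of what the source reports. "The series", "measured", "known", "first", "only" and "open" are said of these compounds alone.

Working notes on a small selenium-bearing series tested in an ADME assay on 184B5 cells (Homo sapiens) for cytotoxicity, read by MTT assay, with a stated time of 72 h; a higher number here means a weaker inhibitor of growth, a lower number a stronger inhibitor of growth.

Compound 2 `CSc1ccc(CNc2nc([SeH])nc3ccccc23)cc1` gives 6840 nM in this assay. Compound 1 `CCCCC[Se]c1nc(NCc2ccc(SC)cc2)c2ccccc2n1` carries the change pentyl in place of hydrogen on a selenium relative to compound 2; in this assay compound 1 gives 57400 nM, so the step of an 8.4-fold higher number from compound 2 to compound 1 (0.92 log units; beyond the scatter) is the only measured effect of that change so far. Compound 3 `Nc1nc([SeH])nc2ccccc12` shares the core with compound 2, but the difference between the two cores is not broken down here; in this assay compound 3 gives 690 nM, the lowest number of the three measured compounds, with compound 2 nearest and compound 1 furthest.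

Compound 4 `CCCCC[Se]c1nc(N)c2ccccc2n1` is not yet measured. It differs from compound 3 by pentyl in place of hydrogen on a selenium. The place line for this change reads the same, word for word, as the place line for the change from compound 2 to compound 1, so it is the same change, now made on the core of compound 3 rather than on the core of compound 2.

The step from compound 3 to compound 4 is expected to be of about the same size as the measured one, an 8.4-fold higher number from compound 3 to compound 4 (0.92 log units; beyond the scatter) beside an 8.4-fold higher number from compound 2 to compound 1 (0.92 log units; beyond the scatter), and this expectation rests on the measured pair compound 2 and compound 1 alone, since the change has been seen only once. Among the measured compounds shown here, for compound 4 the expected value in this assay is 5800 nM, with a range from 1800 nM to 18000 nM, the width reflecting that only one earlier instance of the change supports it.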

Compound 4, concentration for 50% growth inhibition: 15300 nM
Compound 4: the middle estimate sits 2.6-fold (0.42 log units) below what was measured; the range from low to high includes it.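

In this assay the change pentyl in place of hydrogen on a selenium gives a 22-fold higher number from compound 3 to compound 4 (1.35 log units; beyond the scatter) and so raises the number on this second core too. The two instances of the change can be read as one step of similar size, with no difference between the cores that stands out from ordinary repeat variation: the same change on two cores in this assay, an 8.4-fold higher number (0.92 log units; beyond the scatter) from compound 2 to compound 1 and a 22-fold higher number (1.35 log units; beyond the scatter) from compound 3 to compound 4, 2.6-fold (0.42 log units) apart, within the scatter of two such steps. Among the compounds shown here, this supports carrying the change between the core of compound 2 and the core of compound 3 in this assay, with the number rising on both, but it rests on only two pairs and does not show that the step would hold on any further core or explain why the number rises.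

Among the compounds shown, pentyl is the only group other than hydrogen on the selenium, so it remains open whether a shorter chain such as methyl, a longer chain such as octyl, or a chain ending in an amine or a carboxylic acid would give a step of similar size. Going by these compounds, it also remains open whether a benzyl group carrying something other than the methylthio group of compound 2 would leave the step unchanged.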